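The compounds below may be only part of what the source reports. "The series", "measured", "known", "first", "only" and "open" are said of these compounds alone.

Compound 1, `COc1ccc(C(=O)Nc2cccc(-c3oc4cc(-c5ccc(F)cc5)ccc4c(=O)c3O)c2)cc1`, gives 5490 nM in a functional assay on HCC1937 cells (Homo sapiens) for antiproliferative activity, read by CCK-8 assay, with a stated time of 72 h; a lower number here means a stronger inhibitor, a higher number a weaker inhibitor.
Compound 2, `Cc1ccc(C(=O)Nc2cccc(-c3oc4cc(-c5ccc(F)cc5)ccc4c(=O)c3O)c2)cc1`, gives 7110 nM.
Compound 3, `O=C(Nc1cccc(-c2oc3cc(-c4ccc(F)cc4)ccc3c(=O)c2O)c1)c1ccc(F)cc1F`, gives 6980 nM.

Compound 2 carries the largest of the three numbers, but neither neighbour is separated from it by more than the usual scatter: the step of a 1.3-fold higher number from compound 1 to compound 2 (0.11 log units; within the scatter) and the step of a 1.0-fold lower number from compound 2 to compound 3 (0.01 log units; within the scatter) are both small. The three measured compounds therefore stand at practically one level.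

Compound 4, `N#Cc1ccc(C(=O)Nc2cccc(-c3oc4cc(-c5ccc(F)cc5)ccc4c(=O)c3O)c2)cc1`, differs from compound 2 in a single place: cyano in place of methyl on an aromatic carbon.

Going by the values given here, two measured steps touch the same part of the shared core. Swapping methyl for methoxy gave a 1.3-fold higher number from compound 1 to compound 2 (0.11 log units; within the scatter), and swapping 4-methylphenyl for 2,4-difluorophenyl on the carbonyl carbon gave a 1.0-fold lower number from compound 2 to compound 3 (0.01 log units; within the scatter). Neither moved the number beyond the scatter, so the expectation for cyano is likewise no step beyond the scatter in this assay, in either direction. The expected step is a 1.0-fold lower number from compound 2 to compound 4 (0.01 log units; within the scatter). Compound 4 is estimated at 7000 nM, with a range from 3000 nM to 16000 nM.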

Compound 4, half-maximal inhibitory concentration: 2990 nM
Beside the measured number, compound 4's estimate is 2.3-fold (0.37 log units) above it, outside the stated range (below it).
By their numbers in this assay, from the lowest: compounds 4, 1, 3 and 2 (each within the scatter of the next, the first and the last beyond it).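

Cyano on this aromatic carbon, para to a large group, gives the first steps in this small set that pass the scatter in this assay: a 2.4-fold lower number from compound 2 to compound 4 (0.38 log units; beyond the scatter) and a 2.3-fold lower number from compound 3 to compound 4 (0.37 log units; beyond the scatter), both modest. Going by these compounds alone, the position therefore responds to the group it carries, although the earlier compounds gave no sign of this, and the size of that response stays limited: a 1.8-fold lower number from compound 1 to compound 4 (0.26 log units; within the scatter), so cyano cannot be told apart from the methoxy group of compound 1. Nothing available here explains why cyano and methyl differ at this position.

As far as these compounds go, whether a different group at this carbon, such as an amine, a carboxylic acid or a longer chain, would bring the number lower remains open. Also open, from the compounds shown here alone, is whether the step from methyl to cyano would hold in other cell lines.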